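Toward compound 3: a secondary amide on the shared core

The source may hold more compounds than are shown below. What is called first, only, known or untested is meant among the compounds shown, and "the series" means these compounds.

Among the measured compounds shown here, compound 2 `CC(C)c1c(C(=O)N2CCCCC2)nn(-c2ccc(F)cc2)c1OC[C@@H](O)C[C@@H](O)CC(=O)O` gives 32200 nM in a functional assay on L6 cells (Rattus norvegicus) for inhibition (a higher number here means a weaker inhibitor, a lower number a stronger inhibitor), the highest of the two numbers so far; compound 1 `CC(C)c1c(C(=O)N(C)Cc2ccccc2)nn(-c2ccc(F)cc2)c1OC[C@@H](O)C[C@@H](O)CC(=O)O` gives 6720 nM. For the measured compounds named here, the only measured step, a 4.8-fold higher number from compound 1 to compound 2 (0.68 log units; beyond the scatter), bears on the change to compound 3 `CC(C)c1c(C(=O)NCc2ccccc2Cl)nn(-c2ccc(F)cc2)c1OC[C@@H](O)C[C@@H](O)CC(=O)O`, which is (2-chlorobenzyl)amino in place of piperidin-1-yl on a carbonyl carbon. On these data alone, that step moved the number upward when piperidin-1-yl entered, so its partial reversal toward a benzyl-type amide is expected to move the number downward, a 3.6-fold lower number from compound 2 to compound 3 (0.55 log units; beyond the scatter), though the amide hydrogen and the chlorine are untested here. For compound 3 the expected value is 9000 nM, with a range from 2500 nM to 30000 nM.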

Compound 3, half-maximal inhibitory concentration: 8450 nM
Beside the measured number, compound 3's estimate is 1.1-fold (0.03 log units) above it, within the range that was stated.
By their numbers in this assay, from the lowest: compounds 1 and 3 (each within the scatter of the next); then compound 2.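

In this assay the move from piperidin-1-yl to (2-chlorobenzyl)amino gives a 3.8-fold lower number from compound 2 to compound 3 (0.58 log units; beyond the scatter) at this carbonyl carbon, so a secondary benzyl-type amide also departs from the piperidin-1-yl amide. The change from benzyl(methyl)amino gives a 1.3-fold higher number from compound 1 to compound 3 (0.10 log units; within the scatter) and leaves the two benzyl-type amides indistinguishable here, although the amide hydrogen and the chlorine differ together. No supporting evidence accounts for either step.

On these data alone, the separate contributions of the amide hydrogen and the chlorine remain open. An unsubstituted benzylamino group would bear on both.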